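Shortening One Side Chain of Compound 2

The compounds below may be only part of what the source reports. "The series", "measured", "known", "first", "only" and "open" are said of these compounds alone.

Values in a functional assay on HCT-116 cells (Homo sapiens) for inhibition; on this read-out higher numbers stand for weaker inhibition and lower numbers for stronger inhibition:
- Compound 1 `CC(C)=CCC/C(C)=C/C[C@]12C[C@@H](CC=C(C)C)C(C)(C)[C@](CC=C(C)C)(C(=O)CC1=O)C2=O` gives 6.46 ug/mL
- Compound 2 `CC(C)=CCC/C(C)=C/C[C@@H]1C[C@@]2(C/C=C(\C)CCC=C(C)C)C(=O)CC(=O)[C@](CC=C(C)C)(C2=O)C1(C)C` gives the limit > 20 ug/mL
- Compound 3 `CC(C)=CCC/C(C)=C/C[C@]12C[C@@H](CC=C(C)C)C(C)(C)[C@](C/C=C(\C)CCC=C(C)C)(C(=O)CC1=O)C2=O` gives the limit > 20 ug/mL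

Compound 2 has only a limit, > 20 ug/mL, and no number. This is the limit of > 20 ug/mL in this assay, at which 2 of the 3 values shown sit, and compound 3 shares that limit. Only compound 1 has a measured number, 6.46 ug/mL, in this assay.

The next compound to be tested is compound 4 `CC(C)=CCC/C(C)=C/C[C@@H]1C[C@@]2(CC=C(C)C)C(=O)CC(=O)[C@](CC=C(C)C)(C2=O)C1(C)C`. It differs from compound 2 as follows: hydrogen in place of 3-methylbut-2-en-1-yl on a saturated chain carbon bound to a double-bonded chain carbon. Put another way, 3,7-dimethylocta-2,6-dien-1-yl gives way to 3-methylbut-2-en-1-yl.

Within the data shown here, two measured steps bear on this change, and both run the opposite way, adding 3-methylbut-2-en-1-yl. They are an at least 3.0-fold higher number from compound 1 to compound 2 (0.49 log units; beyond the scatter) and an at least 3.0-fold higher number from compound 1 to compound 3 (0.49 log units; beyond the scatter). Both lie beyond the scatter, and both are lower bounds only. Removing the group is therefore expected to move the number down, towards stronger inhibition. Compound 4 is not compound 1, however, and it could still stay at the limit.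

The expected change is an at least 2.5-fold lower number from compound 2 to compound 4 (0.39 log units; beyond the scatter), an estimate that starts from a limit. The estimated value for compound 4 is 8 ug/mL, with an expected range of 3 ug/mL to 25 ug/mL.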

Compound 4, half-maximal inhibitory concentration: 9.14 ug/mL
Compound 4: middle estimate off by 1.1-fold (0.06 log units), on the low side; measured number inside the range.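

In this assay, cutting 3,7-dimethylocta-2,6-dien-1-yl back to 3-methylbut-2-en-1-yl at this position gives an at least 2.1-fold lower number from compound 2 to compound 4 (0.34 log units; beyond the scatter), so the shorter chain here brings the read-out down to a measured number. The earlier compounds showed this change on one core only, starting from compound 1, whereas it now appears on a second core, and on both the longer chain goes with weaker inhibition: the same change on two cores in this assay, an at least 3.0-fold higher number (0.49 log units; beyond the scatter) from compound 1 to compound 3 and an at least 2.1-fold higher number (0.34 log units; beyond the scatter) from compound 4 to compound 2; the limit leaves it open whether they differ Compound 2 carries only a limit, so this step is a lower bound, and compound 2 shares that limit with one other compound: the limit of > 20 ug/mL in this assay, at which 2 of the 4 values shown sit.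

The compounds shown leave open how weak compound 2 and compound 3 really are, and so whether the change costs the same on both cores. They also leave open whether a saturated 3-methylbutyl chain or a plain methyl group in place of 3-methylbut-2-en-1-yl would lower the number further in this assay or lose the inhibition seen with compound 4.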